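The source may report more compounds than this note shows. Statements on the series, on what has been measured and on what is new or still open speak of the compounds shown alone.

Measured compounds:
compound 1 `CC(C)(C)c1ccc(C(=O)N2CCC3(CC2)C(=O)N(CC(=O)N2CCCCC2CCO)CN3c2ccccc2)cc1` with 6100 nM
compound 2 `O=C(CN1CN(c2ccccc2)C2(CCN(C(=O)c3ccc(C4CCCCC4)cc3)CC2)C1=O)NCCO` with 2000 nM

Within the data shown here, compound 1 stands at the highest of the two numbers in an assay on HEK293 cells for displacement of a labelled ligand from NPC1-like intracellular cholesterol transporter 1 (Homo sapiens); on this read-out higher numbers stand for weaker inhibition and lower numbers for stronger inhibition; compound 2 gives the lower value, and that gap is beyond the scatter, though the two compounds differ in more than one place, so no single step is drawn between them.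

Compound 3 `CC(C)(C)c1ccc(C(=O)N2CCC3(CC2)C(=O)N(CC(=O)N2CCCC(O)C2)CN3c2ccccc2)cc1` differs from compound 1 in one place: 3-hydroxypiperidin-1-yl in place of 2-(2-hydroxyethyl)piperidin-1-yl on a carbonyl carbon. Nothing measured here shows this change alone, so the step from compound 1 to compound 3 is expected to be small and within the scatter, with a slight lean toward a lower number, a 1.4-fold lower number from compound 1 to compound 3 (0.13 log units; within the scatter). For compound 3 the estimate in this assay is 4500 nM, with a range from 1500 nM to 13000 nM.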

Compound 3, half-maximal inhibitory concentration: 12200 nM
Compound 3: the middle estimate sits 2.7-fold (0.43 log units) below what was measured; the measured number falls inside the stated range.
By their numbers in this assay, from the lowest: compound 2; then compounds 1 and 3 (each within the scatter of the next).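

In this assay, among these compounds, putting 3-hydroxypiperidin-1-yl in place of 2-(2-hydroxyethyl)piperidin-1-yl on a carbonyl carbon gives a 2.0-fold higher number from compound 1 to compound 3 (0.30 log units; within the scatter), the first one-place comparison at this position. On this read-out the two groups cannot be told apart, although the entering group is the smaller one. No independent measurement bears on this step.

Still open, from the compounds shown here alone, is whether a group of another kind on this carbonyl carbon, such as morpholin-4-yl or a piperidine carrying a carboxylic acid, would shift the number beyond the scatter.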